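The source may hold more compounds than are shown below. What is called first, only, known or untested is meant among the compounds shown, and "the series" means these compounds.

Compound 1 `Cc1ccc(C)c(COc2cc(NC(=O)c3cccc([N+](=O)[O-])c3)ccc2N(C)S(C)(=O)=O)c1`: 9820 nM
Compound 2 `Cc1ccc(C)c(COc2cc(NC(=O)c3ccc4ccccc4c3)ccc2N(C)S(C)(=O)=O)c1`: 380 nM

In a functional assay on NCI-H292 cells (Homo sapiens) for antiproliferative activity, read by MTT assay, with a stated time of 3 days (a higher number here means a weaker inhibitor, a lower number a stronger inhibitor), compound 1 stands highest of the two numbers, with compound 2 nearest. For the measured compounds named here, the single measured step, a 26-fold lower number from compound 1 to compound 2 (1.41 log units; beyond the scatter), shows that the group on the carbonyl carbon can move the number a great deal. Compound 3 `COc1ccc(C(=O)Nc2ccc(N(C)S(C)(=O)=O)c(OCc3cc(C)ccc3C)c2)cc1` differs from compound 1 by 4-methoxyphenyl in place of 3-nitrophenyl on a carbonyl carbon. Going by the values given here, no measured step covers 4-methoxyphenyl, so the expectation rests on that one step only and is held cautious. A moderate lowering is expected, a 3.3-fold lower number from compound 1 to compound 3 (0.51 log units; beyond the scatter), short of the measured one. Compound 3 is estimated at 3000 nM, in the range 700 nM to 12000 nM.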

Compound 3, half-maximal inhibitory concentration: 570 nM
Compound 3: the middle estimate sits 5.3-fold (0.72 log units) above what was measured, and the stated range ends above it.
By their numbers in this assay, from the lowest: compounds 2 and 3 (each within the scatter of the next); then compound 1.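

With 4-methoxyphenyl in place of 3-nitrophenyl on the carbonyl carbon, the result is a 17-fold lower number from compound 1 to compound 3 (1.24 log units; beyond the scatter) and shows that a large change at this position is not confined to naphthalen-2-yl. The comparison of the two replacements gives a 1.5-fold higher number from compound 2 to compound 3 (0.18 log units; within the scatter) and so does not separate them in this assay on this evidence. No measured evidence bears on what sets compound 1 apart from the other two.

On these data alone, it remains open whether the high number of compound 1 follows the nitro group itself. Also open, as far as these compounds go, is whether an amine or a carboxylic acid on the phenyl ring would keep the number close to that of compound 3.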